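A few compounds are considered here, and "the series" means these few. Any claim that something is new, unique, unknown or untested is made for them only; others in the source may bear on it.

Measured in a functional assay on MDA-MB-435 cells (Homo sapiens) for inhibition; a higher number here means a weaker inhibitor, a lower number a stronger inhibitor:
- Compound 1 `COc1cc[nH]c1/C=C1/C(=O)Nc2ccc(F)cc21`: > 30000 nM, a limit and not a number
- Compound 2 `COc1cc[nH]c1/C=C1\C(=O)Nc2ccc(F)c(C#C[C@H](C)O)c21`: 190 nM

Among the measured compounds shown here, compound 2 stands at 190 nM, the only true number in this assay so far. Compound 3 `CN[C@H](C#Cc1c(F)ccc2c1/C(=C/c1[nH]ccc1OC)C(=O)N2)CO` carries 2-hydroxy-1-(methylamino)ethyl in place of 1-hydroxyethyl on a triple-bonded carbon. For the measured compounds named here, no measured step gauges this change, so the only anchor is compound 2 at 190 nM. The expected 1.3-fold lower number from compound 2 to compound 3 (0.10 log units; within the scatter) is therefore none beyond the scatter, though the uncertainty is wide. For compound 3 the estimated value is 150 nM, with an expected range of 40 nM to 600 nM.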

Compound 3, half-maximal inhibitory concentration: 349 nM
Beside the measured number, compound 3's estimate is 2.3-fold (0.37 log units) below it; low and high end bracket the measured number.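

In this assay, the exchange gives a 1.8-fold higher number from compound 2 to compound 3 (0.26 log units; within the scatter) and so shows that 2-hydroxy-1-(methylamino)ethyl is tolerated in place of 1-hydroxyethyl on the triple-bonded carbon, with the two compounds within the scatter of each other. Among the compounds shown here, this is the first measured step at this position, and the larger chain with its added methylamino group costs nothing beyond the scatter. The third value offers no further comparison, as it is a limit and not a number: the limit of > 30000 nM in this assay, at which 1 of the 3 values shown sits.

The compounds shown leave open whether a primary amine, a dimethylamino group or a carboxylic acid on this chain would stand at the same level. Also open, going by these compounds, is what the opposite configuration at the stereocentre would give.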